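The source may hold more compounds than are shown below. What is called first, only, known or untested is meant among the compounds shown, and "the series" means these compounds.

Compound 1 `CN(C)c1ccc(/C=C2\C(=O)N(c3ncc(-c4ccc(Cl)cc4)s3)N=C2c2ccccc2)cc1`: > 206000 nM (a limit of the assay)
Compound 2 `O=C1/C(=C\c2ccccc2)C=C(c2ccccc2)N1c1ccccc1`: 30300 nM

Both compounds were tested in an ADME assay on Huh-5-2 cells (Homo sapiens) for cytotoxicity, read by MTT assay, with a stated time of 72 h; a higher number here means that more compound is tolerated, a lower number that less compound is tolerated. Compound 1 gives no number, only a limit: the limit of > 206000 nM in this assay, at which 1 of the 2 values shown sits.

In this assay, for the measured compounds named here, compound 2 gives 30300 nM, the only actual number available, so it can be placed against no other measured value. Compound 3 `O=C1/C(=C\c2ccc(-c3ccccc3)cc2)C=C(c2ccccc2)N1c1ccccc1` is the next to be measured, and it differs from compound 2 in one place: phenyl in place of hydrogen on an aromatic carbon. Going by the values given here, the data contain no measured step between two compounds that differ in a single place, so they give no direct guide to the size of this one.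

The expectation therefore starts from compound 2 at 30300 nM, with no shift beyond the usual scatter expected in this assay and a wide margin on either side. The estimated change is a 1.2-fold higher number from compound 2 to compound 3 (0.06 log units; within the scatter). Compound 3 is expected at 35000 nM, with an estimated range of 12000 nM to 120000 nM.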

Compound 3, half-maximal cytotoxic concentration: 156000 nM
Compound 3: middle estimate off by 4.5-fold (0.65 log units), on the low side; the whole stated range lies below it.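

In this assay, phenyl in place of hydrogen on an aromatic carbon gives a 5.1-fold higher number from compound 2 to compound 3 (0.71 log units; beyond the scatter), so this carbon, para to a large group, is not indifferent to substitution, and here the change moves the number towards more compound being tolerated. This is a single step with a single entering group, so it shows the direction and size of the change only for phenyl at this place, and nothing in the values says why the number rises. Compound 1 still gives only a limit of the assay, and its core differs from compound 2 in more than one place, so it adds no second step to set beside this one: the limit of > 206000 nM in this assay, at which 1 of the 3 values shown sits.

On these data alone, it remains open whether the rise depends on the aromatic ring itself, or whether a methyl group, a methoxy group or a carboxylic acid on the same carbon would shift the number as far. As far as these compounds go, it is equally open whether phenyl at another carbon of that ring would give a step of this size, and whether the change would carry over to the core of compound 1.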